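The source may report more compounds than this note shows. Statements on the series, on what has been measured and on what is new or still open speak of the compounds shown alone.

Measured compounds:
- compound 1 `O=C(CCN1C(=O)CSc2ccccc21)N1CCN(c2ccc([N+](=O)[O-])cc2)CC1`: in a functional assay on IMR-32 cells (Homo sapiens) for inhibition, read by sulforhodamine B assay, with a stated time of 48 h (a lower number here means a stronger inhibitor of growth, a higher number a weaker inhibitor of growth), compound 1 gives 340 nM
- compound 2 `O=C(CCN1C(=O)CSc2ccccc21)N1CCN(c2ccc(C(F)(F)F)cc2)CC1`: in this assay compound 2 gives 46400 nM
- compound 3 `O=C(CCN1C(=O)CSc2ccccc21)N1CCN(c2ccccc2F)CC1`: in this assay compound 3 gives > 100000 nM, which is a limit of the assay and not a number

All three compounds share one core and differ only in the aromatic ring on the piperazine nitrogen. Compound 3 stands at the top edge of what the assay reports, at the limit of > 100000 nM in this assay, at which 1 of the 3 values shown sits; its true value may lie anywhere beyond that.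

Compound 4 `O=C(CCN1C(=O)CSc2ccccc21)N1CCN(c2ccccc2)CC1` differs from compound 3 by hydrogen in place of fluoro on an aromatic carbon, so the step is simply the loss of one fluorine.

Going by the values given here, no measured step removes a fluorine alone. The steps that touch the 2-fluorophenyl ring, an at least 290-fold higher number from compound 1 to compound 3 (2.46 log units; beyond the scatter) and an at least 2.1-fold higher number from compound 2 to compound 3 (0.33 log units; beyond the scatter), both swap the whole ring and both move in the weaker direction, and a 140-fold higher number from compound 1 to compound 2 (2.14 log units; beyond the scatter) shows how strongly the group on this ring sways the number. Nothing among them tells whether the fluorine itself helps or hurts, so no large step in either direction is expected in this assay, and compound 4 is expected to remain near the limit.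

Compound 4 is estimated at 150000 nM, with a range from 30000 nM to 600000 nM, which means an expected step that the limit leaves unreadable from compound 3 to compound 4.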

Compound 4, concentration for 50% growth inhibition: < 10 nM
Compound 4 gave a limit, no number; the forecaster's own chance of this, stated with the estimate: 65%; middle value at least 15000-fold (4.17 log units) away from the limit.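

In this assay compound 4 sits at a limit of the assay, not at a number: the limit of < 10 nM in this assay, at which 1 of the 4 values shown sits. Losing one fluorine, ortho to a large group, gives an at least 10000-fold lower number from compound 3 to compound 4 (4.00 log units; beyond the scatter), so a single atom at this place separates the weakest reading the assay reports from the strongest, and the plain phenyl ring, with no added group, is the strongest inhibitor of growth of the four. Hydrogen also beats the other two groups, with trifluoromethyl giving way in an at least 4600-fold lower number from compound 2 to compound 4 (3.66 log units; beyond the scatter) and nitro in an at least 34-fold lower number from compound 1 to compound 4 (1.53 log units; beyond the scatter), so all three groups shown lower activity relative to plain phenyl.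

Going by these compounds, because both ends are limits, the true size of the step from fluoro to hydrogen stays unknown. On these data alone, whether a methyl group or an amine on this ring would keep the activity of compound 4 also remains open.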